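A few compounds are considered here, and "the series" means these few. Any claim that something is new, unique, unknown or untested is made for them only; others in the source may bear on it.

Measured in a functional assay on SH-SY5Y cells (Homo sapiens) for cytotoxicity, read by MTT assay, with a stated time of 72 h; on this read-out lower numbers stand for stronger inhibition and higher numbers for weaker inhibition:

Compound 1 `O=C1c2c[n+]([O-])c3ccccc3c2C(=O)c2c1c1ccccc1n2Cc1cn([C@H]2O[C@H](CO)[C@@H](O)[C@H]2O)nn1` gives 1340 nM
Compound 2 `CN1CCN(CCCCn2c3c(c4ccccc42)C(=O)c2c[n+]([O-])c4ccccc4c2C3=O)CC1` gives 100 nM
Compound 3 `O=C1c2c[n+]([O-])c3ccccc3c2C(=O)c2c1c1ccccc1n2CCN1CCCC1` gives 520 nM

Compound 1 has the highest number of the three, so it is the least potent of this small set. Compound 3 lies closest to it and compound 2 furthest away, both clearly lower. The next compound to be tested is compound 4 `CC1(C)OC[C@@H](Cn2cc(Cn3c4c(c5ccccc53)C(=O)c3c[n+]([O-])c5ccccc5c3C4=O)nn2)O1`, which keeps the core of compound 1 and swaps one side group: (2,2-dimethyl-1,3-dioxolan-4-yl)methyl in place of 3,4-dihydroxy-5-(hydroxymethyl)oxolan-2-yl on an aromatic nitrogen.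

Within the data shown here, no measured step involves this exact swap. The only one available is a 5.2-fold higher number from compound 2 to compound 3 (0.72 log units; beyond the scatter), with pyrrolidin-1-yl in place of 2-(4-methylpiperazin-1-yl)ethyl, and it concerns a different group. It therefore offers only a rough guide to how far a change of side group can move the number. With compound 1 at 1340 nM as the top of the set, a lower number is more likely than a higher one in this assay, though this is only a modest expectation. Among the measured compounds shown here, the expected change is a 2.7-fold lower number from compound 1 to compound 4 (0.43 log units; beyond the scatter), similar in size to the one measured step. For compound 4 the estimated value is 500 nM, with an expected range from 150 nM to 1600 nM.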

Compound 4, half-maximal inhibitory concentration: > 1000 nM
Compound 4 gave a limit, no number; the forecaster's own chance of this, stated with the estimate: 3%; at least 2.0-fold (0.30 log units) between middle value and limit.
By their numbers in this assay, from the lowest: compound 2; then compound 3; then compound 1.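

In this assay, among these compounds, compound 4 gives > 1000 nM, which is a limit and not a number, so no step from compound 1 to compound 4 can be read. The compounds shown leave open how far, and in which direction, the number moves when (2,2-dimethyl-1,3-dioxolan-4-yl)methyl replaces 3,4-dihydroxy-5-(hydroxymethyl)oxolan-2-yl.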